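The source may hold more compounds than are shown below. What is called first, only, known or untested is meant among the compounds shown, and "the series" means these compounds.

Measured so far, in a functional assay on HEK293 cells for agonist activity at G-protein coupled receptor 39 (Homo sapiens), read by scintillation proximity assay and inositol phosphate accumulation, with a stated time of 75 min, in the presence of a further agent that is not named here; a higher number here means that more compound is needed for the effect, a lower number that less compound is needed:
- compound 1 `CCC(C(=O)NC1CC(=O)Nc2c1c(C)nn2-c1ncnc2nc[nH]c12)c1ccccc1`: 5 nM
- compound 2 `Cc1nn(-c2ncnc3nc[nH]c23)c2c1C(OC(=O)c1ccc(F)cc1)CC(=O)N2`: 4 nM

Compound 2 gives the lower of the two numbers, yet the gap to compound 1 lies within the scatter, so the two read as equivalent in this assay.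

Compound 3 `Cc1nn(-c2ncnc3nc[nH]c23)c2c1C(OCC(C)C)CC(=O)N2` is the next step from compound 2. The change is isobutyl in place of (4-fluorophenyl)carbonyl on an oxygen on a saturated carbon. Going by the values given here, no measured pair in this set carries a comparable swap, so the size of the step is open. A loss beyond the scatter is expected in this assay, with the step of a 7.5-fold higher number from compound 2 to compound 3 (0.88 log units; beyond the scatter) as the working assumption. Compound 3 is thus estimated at 30 nM, with a range from 8 nM to 150 nM.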

Compound 3, half-maximal effective concentration: 4 nM
Compound 3: middle estimate off by 7.5-fold (0.88 log units), on the high side, and the stated range ends above it.
By their numbers in this assay, from the lowest: compounds 2, 3 and 1 (each within the scatter of the next).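

In this assay, the oxygen on the saturated carbon accepts isobutyl in place of (4-fluorophenyl)carbonyl, with no change at the digits printed from compound 2 to compound 3 (within the scatter) across this exchange. For this pair, neither the six-membered aromatic ring nor the carbonyl of the leaving group is needed to keep the number in this range, and a smaller group without a ring serves equally. No supporting data bear on why the two groups read alike.

Going by these compounds, whether a longer chain on this oxygen gives the same reading stays open. So does the effect of a chain ending in an amine or a carboxylic acid.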